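The compounds below may be only part of what the source reports. "The series", "measured", "known", "first", "only" and "open" are said of these compounds alone.

In a toxicity assay on BJ cells (Homo sapiens) for cytotoxicity, read by MTT assay, with a stated time of 24 h (on this read-out higher numbers stand for weaker inhibition and lower numbers for stronger inhibition), three compounds have been measured so far. Compound 1 `CCOC(=O)N1CCC(=NNC(=O)c2ccc(F)cc2)CC1` carries its carbonyl on a different core from the other two; in this assay compound 1 reaches only > 400000 nM, which is a limit of the assay and not a number. Compound 2 `COc1ccc(C(=O)NN=C2CC(c3ccccc3)NC(c3ccccc3)C2)cc1` and compound 3 `O=C(NN=C1CC(c2ccccc2)NC(c2ccccc2)C1)c1ccc([N+](=O)[O-])cc1[N+](=O)[O-]` share a core. Compound 2 gives in this assay > 400000 nM, again a limit rather than a measured number. Compound 3 likewise sits at a limit, > 400000 nM. Within the data shown here, compound 2 therefore stands exactly where every measured compound stands, as the limit of > 400000 nM in this assay, at which 3 of the 3 values shown sit, shows, and no step between measured compounds can be computed from these data.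

Compound 4 `O=C(NN=C1CC(c2ccccc2)NC(c2ccccc2)C1)c1ccc(F)cc1C(F)(F)F` differs from compound 2 in one place: 4-fluoro-2-(trifluoromethyl)phenyl in place of 4-methoxyphenyl on a carbonyl carbon. Since every measured value in this assay is a limit, neither a direction nor a size of step can be read off for this kind of change, and the plain expectation is that the change from compound 2 to compound 4 produces no step beyond the usual scatter, with the reading once more most likely a limit. Compound 4 is therefore expected at about 450000 nM, within a range of 250000 nM to 1000000 nM. That expectation corresponds to an estimated step that the limit leaves unreadable from compound 2 to compound 4.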

Compound 4, half-maximal inhibitory concentration: > 400000 nM
Compound 4: only a limit was reported; the forecaster's own chance of this, stated with the estimate: 85%; the middle value lies beyond the limit too.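

In this assay compound 4 gives > 400000 nM, which is a limit of the assay and not a number. Among these compounds, compound 2 sits at a limit too, so no step between compound 2 and compound 4 can be read: the limit of > 400000 nM in this assay, at which 4 of the 4 values shown sit. The compounds shown leave open what change in structure, if any, would bring a measurable value in this test.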